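Replacing 2,4-dimethoxyphenyl with 3-hydroxyphenyl in compound 3

This account rests on a few compounds, and the source may have more. Where it says the series, first, only, none or still open, it means among the compounds named here.

Compound 1 (`COc1cc(-c2cc(-c3ccc(Cl)cc3)nc(-c3ccccc3)n2)cc(OC)c1OC`): 6230 nM
Compound 2 (`COc1ccc(-c2cc(-c3cc(OC)c(OC)c(OC)c3)nc(-c3ccccc3)n2)c(OC)c1`): > 25000 nM (a limit)

In a functional assay on HT-29 cells (Homo sapiens) for inhibition, read by MTT assay, with a stated time of 48 h (on this read-out higher numbers stand for weaker inhibition and lower numbers for stronger inhibition), compound 2 stands at > 25000 nM, which is a limit and not a number. Compound 3 (`COc1cc(-c2cc(-c3cccc(O)c3)nc(-c3ccccc3)n2)cc(OC)c1OC`) carries 3-hydroxyphenyl in place of 2,4-dimethoxyphenyl (3-hydroxyphenyl in place of 2,4-dimethoxyphenyl on an aromatic carbon). Within the data shown here, the only measured step at this place is an at least 4.0-fold higher number from compound 1 to compound 2 (0.60 log units; beyond the scatter) and it lies beyond the scatter, with 2,4-dimethoxyphenyl replacing 4-chlorophenyl. Among the measured compounds shown here, compound 1 at 6230 nM is the only true number available, so a move back toward lower numbers seems likely, though its size is uncertain. The expected change in this assay is an at least 2.7-fold lower number from compound 2 to compound 3 (0.44 log units; beyond the scatter) as estimated. For compound 3 the estimated value is 9000 nM (range 2500 nM to 25000 nM).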

Compound 3, half-maximal inhibitory concentration: > 25000 nM
Compound 3 ended at the assay's limit; the forecaster's own chance of this, stated with the estimate: 20%; middle value at least 2.7-fold (0.44 log units) away from the limit.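

In this assay, 3-hydroxyphenyl in place of 4-chlorophenyl also weakens inhibition, with an at least 4.0-fold higher number from compound 1 to compound 3 (0.60 log units; beyond the scatter). Two different replacements now fall short of 4-chlorophenyl, which leaves compound 1, at 6230 nM, as the only compound shown here with a true number. The step between compound 2 and compound 3 cannot be read because both stop at the limit: the limit of > 25000 nM in this assay, at which 2 of the 3 values shown sit.

From the compounds shown here alone, whether compound 2 and compound 3 truly differ remains open. Also open, going by these compounds, is how a 4-aminophenyl or 4-carboxyphenyl group at this position would compare with 4-chlorophenyl.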